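Reversing the piperazine amide switch in the quinoline series

A few compounds are considered here, and "the series" means these few. Any claim that something is new, unique, unknown or untested is made for them only; others in the source may bear on it.

Compound 1 `COc1ncc(-c2ccc3nccc(/C(C)=C/C(=O)N4CCC(O)CC4)c3c2)cc1NS(=O)(=O)c1ccc(F)cc1F`: 600 nM
Compound 2 `COc1ncc(-c2ccc3nccc(/C(C)=C/C(=O)N4CCOCC4)c3c2)cc1NS(=O)(=O)c1ccc(F)cc1F`: 610 nM
Compound 3 `COc1ncc(-c2ccc3nccc(/C=C/C(=O)N4CCN(C)CC4)c3c2)cc1NS(=O)(=O)c1ccc(F)cc1F`: 220 nM

In a functional assay on U-87MG ATCC cells for inhibition, with U-87 MG (Homo sapiens) as the target, read by sulforhodamine B assay, with a stated time of 72 h (a lower number here means a stronger inhibitor of growth, a higher number a weaker inhibitor of growth), compound 3 gives the lowest number of the three, with compound 1 and compound 2 each beyond the scatter above it. Compound 4 `COc1ncc(-c2ccc3nccc(/C(C)=C\C(=O)N4CCOCC4)c3c2)cc1NS(=O)(=O)c1ccc(F)cc1F` differs from compound 3 by 1-methyl-2-((morpholin-4-yl)carbonyl)ethenyl in place of 2-((4-methylpiperazin-1-yl)carbonyl)ethenyl on an aromatic carbon. This change runs the measured step of a 2.8-fold lower number from compound 2 to compound 3 (0.44 log units; beyond the scatter) backwards, and the related step of a 2.7-fold lower number from compound 1 to compound 3 (0.44 log units; beyond the scatter) points the same way, so a rise of similar size is expected for compound 4. The step of a 1.0-fold higher number from compound 1 to compound 2 (0.01 log units; within the scatter) shows that the ring exchange alone adds little. Compound 4 is therefore expected to give 650 nM (range 250 nM to 1800 nM), an estimated step of a 3.0-fold higher number from compound 3 to compound 4 (0.47 log units; beyond the scatter).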

Compound 4, concentration for 50% growth inhibition: > 10000 nM
Compound 4 ended at the assay's limit; the forecaster's own chance of this, stated with the estimate: 3%; middle value at least 15-fold (1.18 log units) away from the limit.
By their numbers in this assay, from the lowest: compound 3; then compounds 1 and 2 (each within the scatter of the next). At a limit, above all of these: compound 4.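

At this position the configuration of the double bond outweighs the earlier changes: going from E to Z gives an at least 16-fold higher number from compound 2 to compound 4 (1.21 log units; beyond the scatter), and nothing else changes: the fact that compounds 2 and 4 differ only in the configuration as drawn
The steps of an at least 45-fold higher number from compound 3 to compound 4 (1.65 log units; beyond the scatter) and an at least 16-fold higher number from compound 1 to compound 4 (1.22 log units; beyond the scatter) are equally large, but each also exchanges the amide ring.
Compound 4 stands at a limit, not at a number: the limit of > 10000 nM in this assay, at which 1 of the 4 values shown sits.

The compounds shown leave open whether the methyl group on the ethenyl or the 4-methylpiperazin-1-yl ring accounts for the lower number of compound 3. They also leave open whether a Z double bond carrying 4-methylpiperazin-1-yl or a carboxylic acid would behave like compound 4.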